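The compounds below may be only part of what the source reports. "The series", "measured", "known", "first", "only" and "open" are said of these compounds alone.

Of the compounds shown here, two that share one core have been tested in a functional assay on DLA cells (Mus musculus) for cytotoxicity, read by trypan blue exclusion, with a stated time of 48 h; a higher number here means a weaker inhibitor, a lower number a stronger inhibitor. Compound 2, `Cc1cc(C(=O)c2ccccc2)cc(C)c1OCC(=O)Nc1nc(-c2ccccc2)cs1`, gives 19100 nM in this assay. Compound 1, `COc1ccc(-c2csc(NC(=O)COc3ccc(C(=O)c4ccccc4)cc3C)n2)cc1`, gives 24200 nM in this assay. The two values sit within the usual scatter of each other, so on these numbers the two compounds cannot be told apart, even though compound 2 shows the lower of the two figures.

Compound 3, `COc1ccc(-c2csc(NC(=O)COc3c(C)cc(C(=O)c4ccccc4)cc3C)n2)cc1`, has not yet been measured. It differs from compound 2 in a single place: methoxy in place of hydrogen on an aromatic carbon. Within the data shown here, no measured pair of compounds differs by exactly this change, so nothing observed fixes its size. Compound 1 also carries a methoxy group, though it differs from compound 2 in a second place as well, and compound 1 at 24200 nM and compound 2 at 19100 nM lie within the scatter of each other. The step of a 1.0-fold higher number from compound 2 to compound 3 (0.02 log units; within the scatter) is therefore expected to be none beyond the scatter. Compound 3 is expected to give about 20000 nM in this assay, with a range from 9000 nM to 45000 nM.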

Compound 3, half-maximal inhibitory concentration: 38400 nM
Compound 3: middle estimate off by 1.9-fold (0.28 log units), on the low side; the measured number falls inside the stated range.
By their numbers in this assay, from the lowest: compounds 2, 1 and 3 (each within the scatter of the next).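

Among these compounds, the first direct pair for phenyl to 4-methoxyphenyl reads a 2.0-fold higher number from compound 2 to compound 3 (0.30 log units; within the scatter) in this assay, so on these numbers methoxy cannot be told apart from hydrogen at this place, para to a large group. The second pair, which differs by a single added methyl group, reads a 1.6-fold higher number from compound 1 to compound 3 (0.20 log units; within the scatter) and also stays inside the usual scatter, so neither single swap is shown to matter in this small set. No accompanying measurement speaks to how either group acts on these cells, and the numbers alone can say nothing more about it.

As far as these compounds go, whether a different group at the same place, such as an amine, a carboxylic acid or a longer alkoxy chain, would give a step beyond the scatter remains open. Among the compounds shown here, also open is whether methoxy in place of hydrogen would read the same on the core of compound 1, which would show whether this result holds beyond the single pair seen here.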